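The source may hold more compounds than are shown below. What is called first, only, known or untested is meant among the compounds shown, and "the series" means these compounds.

The measured compounds are compound 1 `CC1=C(C(=O)Nc2ccc(F)cc2)C(c2ccc([N+](=O)[O-])cc2)N=C(SCc2cccc(Cl)c2)N1` with 9.8%, compound 2 `CC1=C(C(=O)Nc2ccc(F)cc2)C(c2ccc([N+](=O)[O-])cc2)N=C(SCc2ccc(Cl)cc2)N1` with 16%, and compound 3 `CC1=C(C(=O)Nc2ccc(Br)cc2)C(c2ccc(Cl)cc2Cl)N=C(SCc2cccc(Cl)c2)N1` with 8.8%.

All three were tested in a functional assay on the whole organism (artery, strain albino) with Rattus norvegicus as the target, with a stated time of 120 min, at a dose of 10 mg/kg by the oral route; on this read-out lower numbers stand for less inhibition and higher numbers for more inhibition at the one dose given (going by the name of the read-out). Compound 1 and compound 2 share the same core and differ in one place only: 4-chlorophenyl in place of 3-chlorophenyl on a saturated chain carbon bound to a sulfur. That change gave a number 6.2 percentage points higher from compound 1 to compound 2 (within the scatter). In this assay compound 3 gives 8.8%; how its core differs from the core of compound 1 is not broken down here. Compound 4 `CC1=C(C(=O)Nc2ccc(Br)cc2)C(c2ccc(Cl)cc2Cl)N=C(SCc2ccc(Cl)cc2)N1` has not yet been measured in this assay. It stands to compound 3 as compound 2 stands to compound 1: 4-chlorophenyl in place of 3-chlorophenyl on a saturated chain carbon bound to a sulfur. The place of the change is the same in both pairs, so this is the same change made on a different core. It is expected that the step from compound 3 to compound 4 will be of a similar size, a number 5.2 percentage points higher from compound 3 to compound 4 (within the scatter), because in the pair already measured the same change gave a number 6.2 percentage points higher from compound 1 to compound 2 (within the scatter). On that basis compound 4 is estimated at 14% in this assay. The expected range for compound 4 runs from 3% to 26%. Among the measured compounds shown here, only one earlier instance of the change is known, and that step lay within the scatter; the expectation is accordingly a loose one.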

Compound 4, a percentage reported as inhibition, in the whole organism at one dose (the size of the read-out at that dose, not a potency): 17.5%
Compound 4: middle estimate off by 3.5 percentage points, on the low side, and the stated range covers the measured number.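

In this assay, 4-chlorophenyl in place of 3-chlorophenyl on a saturated chain carbon bound to a sulfur gave a number 8.7 percentage points higher from compound 3 to compound 4 (within the scatter). Set beside the earlier instance, the two steps cannot be told apart: the same change on two cores in this assay, a number 6.2 percentage points higher (within the scatter) from compound 1 to compound 2 and a number 8.7 percentage points higher (within the scatter) from compound 3 to compound 4, 2.5 percentage points apart, within the scatter of two such steps

This shows that the change gives steps of comparable size on these two cores, so the earlier step was a fair guide to the new one. It does not show that the change itself has a real effect on either core, since each step lies within the scatter, and two cores are too few to support a rule for the rest of the series.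

The compounds shown leave open whether an unsubstituted benzyl, a fluorobenzyl or a longer alkyl chain in place of the chlorobenzyl group would give similar numbers, and the same holds for a group carrying an amine or a carboxylic acid. They also leave open whether the step would look the same at another dose or time.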